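One fluoro on the phenyl of compound 3

The source may report more compounds than this note shows. Statements on the series, on what has been measured and on what is new or still open speak of the compounds shown alone.

Of the compounds shown here, three sharing one core have been tested in a functional assay on SGC-7901 cells (Homo sapiens) for cytotoxicity, read by sulforhodamine B assay, with a stated time of 72 h; on this read-out higher numbers stand for weaker inhibition and lower numbers for stronger inhibition. Compound 1 `C=C1C(=O)O[C@@H]2CC(C)=C([C@@H](C)CCCOC(C)=O)[C@@H](OC(=O)CCl)[C@H]12`, with chloromethyl on the ester carbonyl, gives 26500 nM. Compound 2 `C=C1C(=O)O[C@@H]2CC(C)=C([C@@H](C)CCCOC(C)=O)[C@@H](OC(=O)COc3cccc4[nH]nnc34)[C@H]12`, with a larger ring-bearing group in that place, gives 21100 nM. That is a 1.3-fold lower number from compound 1 to compound 2 (0.10 log units; within the scatter). Compound 3 `C=C1C(=O)O[C@@H]2CC(C)=C([C@@H](C)CCCOC(C)=O)[C@@H](OC(=O)c3ccccc3)[C@H]12`, with phenyl on the same carbonyl, gives 9930 nM, the lowest of the three numbers and so the strongest inhibition seen so far.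

Compound 4 `C=C1C(=O)O[C@@H]2CC(C)=C([C@@H](C)CCCOC(C)=O)[C@@H](OC(=O)c3ccc(F)cc3)[C@H]12` differs from compound 3 by fluoro in place of hydrogen on an aromatic carbon, para to a large group, which turns phenyl into 4-fluorophenyl. Within the data shown here, no tested pair makes this change. The closest evidence is the two steps that swapped a whole group on the carbonyl, and both stayed modest: a 2.7-fold lower number from compound 1 to compound 3 (0.43 log units; beyond the scatter) and a 2.1-fold lower number from compound 2 to compound 3 (0.33 log units; beyond the scatter). Exchanging one hydrogen is a far smaller edit than either, so no shift beyond the scatter is expected in this assay. The expected change is a 1.0-fold lower number from compound 3 to compound 4 (0.02 log units; within the scatter). Compound 4 is estimated at 9500 nM, with an expected range from 4500 nM to 20000 nM.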

Compound 4, half-maximal inhibitory concentration: 13600 nM
The estimate for compound 4 lay 1.4-fold (0.16 log units) below the measured number, within the range that was stated.
By their numbers in this assay, from the lowest: compounds 3, 4, 2 and 1 (each within the scatter of the next, the first and the last beyond it).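

In this assay, among these compounds, this is the first edit of a single atom on the ring of compound 3, and a 1.4-fold higher number from compound 3 to compound 4 (0.14 log units; within the scatter) shows that fluoro in place of hydrogen on this aromatic carbon, para to a large group, leaves the number within the scatter. Compound 3 stood beyond the scatter from both other esters, but compound 4 does not, with a 1.6-fold lower number from compound 2 to compound 4 (0.19 log units; within the scatter) and a 1.9-fold lower number from compound 1 to compound 4 (0.29 log units; within the scatter) both printed as within it, so the small separation seen with phenyl is not seen with 4-fluorophenyl. Nothing measured here bears on what lies behind this result.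

The compounds shown leave open whether a different group on this same aromatic carbon, such as methoxy, an amine or a carboxylic acid, would move the number beyond the scatter. Also open, going by these compounds, is whether fluoro on one of the other carbons of this ring would give a number within the scatter of compound 3 as well.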